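This account rests on a few compounds, and the source may have more. Where it says the series, first, only, none or still open, it means among the compounds named here.

The compounds here share one core, on which the aryl group at the far end varies. Compound 1 `Cn1c(=O)c(=O)n(C2CCCC2)c2nc(N/N=C/c3cc(C(F)(F)F)c(O)c(C(F)(F)F)c3)ncc21` carries a ring bearing two trifluoromethyl groups and a hydroxy; in a functional assay on A549 cells (Homo sapiens) for antiproliferative activity, read by MTT assay (a higher number here means a weaker inhibitor, a lower number a stronger inhibitor), compound 1 gives 22900 nM. Compound 3 `Cn1c(=O)c(=O)n(C2CCCC2)c2nc(N/N=C/c3cc(C(F)(F)F)cc(C(F)(F)F)c3)ncc21` lacks that hydroxy, and in this assay compound 3 gives 3230 nM. Within the data shown here, the step of a 7.1-fold lower number from compound 1 to compound 3 (0.85 log units; beyond the scatter) is the only single-change step among the measured compounds. Compound 2 `Cn1c(=O)c(=O)n(C2CCCC2)c2nc(N/N=C/c3ccco3)ncc21` carries a furan-2-yl group instead of a substituted phenyl. In this assay compound 2 gives > 100000 nM, which is the limit of the assay and not a number (the limit of > 100000 nM in this assay, at which 1 of the 3 values shown sits). Compound 2 thus stands at the weak end of what has been measured: both phenyl-bearing compounds gave a number, while compound 2 did not.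

The unmeasured compound 4 `Cn1c(=O)c(=O)n(C2CCCC2)c2nc(N/N=C/c3cccc([N+](=O)[O-])c3)ncc21` changes exactly this part: 3-nitrophenyl in place of furan-2-yl on a carbon with a double bond to nitrogen. Among the measured compounds shown here, no measured step covers the exchange of a furan ring for a phenyl ring; the one measured step, a 7.1-fold lower number from compound 1 to compound 3 (0.85 log units; beyond the scatter), concerns a hydroxy on a phenyl ring and does not bear directly on it. The numbers do show that compounds 1 and 3 reached measurable values where compound 2 reached only the limit. A gain toward a measurable number is therefore expected for compound 4, an at least 3.3-fold lower number from compound 2 to compound 4 (0.52 log units; beyond the scatter), though the limit may again be reported. Compound 4 is estimated at 30000 nM in this assay, between 8000 nM and 100000 nM.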

Compound 4, half-maximal inhibitory concentration: 12300 nM
Compound 4: middle estimate off by 2.4-fold (0.39 log units), on the high side, within the range that was stated.
By their numbers in this assay, from the lowest: compound 3; then compounds 4 and 1 (each within the scatter of the next). At a limit, above all of these: compound 2.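

In this assay, replacing furan-2-yl with 3-nitrophenyl on the carbon with a double bond to nitrogen gives an at least 8.1-fold lower number from compound 2 to compound 4 (0.91 log units; beyond the scatter), so the ring at this position matters, and not only the groups on a phenyl ring as the earlier step showed. This step can only be given as a minimum, since one end of it is a limit and not a number: the limit of > 100000 nM in this assay, at which 1 of the 4 values shown sits.

Compound 4 has a nitro group and neither a trifluoromethyl nor a hydroxy group, yet it still reaches a measurable value, so among the compounds shown a measurable value does not depend on the trifluoromethyl groups carried by compound 1 and compound 3.

The change replaces the ring and brings in the nitro group at the same time, so the compounds shown cannot say how much of the gain belongs to each. From the compounds shown here alone, how a plain phenyl ring, or a phenyl ring carrying an amine or a carboxylic acid instead of the nitro group, would behave in this assay remains open.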